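Pentylselanyl in place of sulfanyl on the shared core

The source may hold more compounds than are shown below. What is called first, only, known or untested is meant among the compounds shown, and "the series" means these compounds.

compound 1 `CCCCC[Se]c1nc([Se]CCCCC)c2ccccc2n1` — only a limit of > 100000 nM in an ADME assay on 184B5 cells (Homo sapiens) for cytotoxicity, read by MTT assay, with a stated time of 72 h; a lower number here means a stronger inhibitor of growth, a higher number a weaker inhibitor of growth
compound 2 `Sc1nc(NCc2ccccc2)c2ccccc2n1` — only a limit of > 100000 nM in this assay

Among the measured compounds shown here, both values sit at the assay limit (the limit of > 100000 nM in this assay, at which 2 of the 2 values shown sit), so compound 2 stands only at a limit, with the one further value shown also a limit. Compound 3 `CCCCC[Se]c1nc(NCc2ccccc2)c2ccccc2n1` differs from compound 2 by a group of 6 heavy atoms (5 carbon, 1 selenium; no ring) in place of one sulfur atom, on an aromatic carbon. For the measured compounds named here, no step between measured compounds is available; the change a number no higher from compound 2 to compound 3 (the limit leaves the size open) is expected to be none beyond the scatter. Compound 3 is estimated at 100000 nM, with a range of 30000 nM to 300000 nM.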

Compound 3, concentration for total growth inhibition: > 100000 nM
Compound 3 gave a limit, no number (the forecaster's own chance of this, stated with the estimate: 75%); the middle value sits exactly at the limit.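

No step can be read from compound 2 to compound 3 or from compound 1 to compound 3, because each compound gives only a limit: the limit of > 100000 nM in this assay, at which 3 of the 3 values shown sit.

The compounds shown leave open whether pentylselanyl in place of sulfanyl changes growth inhibition at all.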